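Swapping Ethyl for 4-Fluorophenyl on a Kinase Inhibitor

This account rests on a few compounds, and the source may have more. Where it says the series, first, only, none or still open, it means among the compounds named here.

Compound 2 `CCc1cc(-c2nn(C(C)C)c3ncnc(N)c23)no1` is one of three compounds tested in an assay on isolated protein for inhibition of proto-oncogene tyrosine-protein kinase receptor Ret (Homo sapiens), read by radiometric assay and 33P incorporation, in the presence of a further agent that is not named here; on this read-out higher numbers stand for weaker inhibition and lower numbers for stronger inhibition. Compound 2 gives 41 nM, the second highest of the three numbers: compound 1 `CC(C)n1nc(-c2cc(-c3ccccc3)on2)c2c(N)ncnc21` gives 190 nM, and compound 3 `Nc1ncnc2c1c(-c1cc(C3CC3)on1)nn2C1CCOCC1` gives 5 nM. Compound 4 `CC(C)n1nc(-c2cc(-c3ccc(F)cc3)on2)c2c(N)ncnc21` differs from compound 2 at a single place: 4-fluorophenyl in place of ethyl on an aromatic carbon. Within the data shown here, the one measured step that bears on this change runs the other way, a 4.6-fold lower number from compound 1 to compound 2 (0.67 log units; beyond the scatter), where ethyl replaced phenyl. Reversing that swap should undo most of the gain it brought, so a higher number of roughly the same size is expected for compound 4, a 3.7-fold higher number from compound 2 to compound 4 (0.56 log units; beyond the scatter). The estimate for compound 4 is 150 nM, with a range from 60 nM to 400 nM.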

Compound 4, half-maximal inhibitory concentration: 150 nM
The estimate for compound 4 equals the measured number at the digits printed; the range from low to high includes it.
By their numbers in this assay, from the lowest: compound 3; then compound 2; then compounds 4 and 1 (each within the scatter of the next).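

Ethyl and an aromatic ring at this position now differ in a second pair, with a 3.7-fold higher number from compound 2 to compound 4 (0.56 log units; beyond the scatter), so the earlier gap is not confined to plain phenyl. Fluoro in place of hydrogen on that ring gives no step that can be told from the scatter, with a 1.3-fold lower number from compound 1 to compound 4 (0.10 log units; within the scatter), so among these compounds the higher numbers go with the ring, with or without fluoro. No measurement here offers an explanation for this. As far as these compounds go, whether a longer chain or an amine on this carbon would read closer to compound 2 or to compound 4 remains open.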